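The compounds below may be only part of what the source reports. "The series", "measured", "known", "first", "only" and "open" are said of these compounds alone.

Compound 2, `CCOCn1cc(C#N)c2c(N)ncnc21`, carries a nitrile and an ethoxymethyl chain on the shared core. In a functional assay on KB cells (Homo sapiens) for cytotoxicity (on this read-out lower numbers stand for stronger inhibition and higher numbers for weaker inhibition), compound 2 gives only a limit of the assay, > 100000 nM. Compound 3, `CCOCn1cc(C(N)=O)c2c(N)ncnc21`, differs from compound 2 by cyano in place of carbamoyl on an aromatic carbon. Compound 3 likewise reaches only a limit in this assay, > 100000 nM. The step that the two limits leave unreadable from compound 2 to compound 3 therefore cannot be sized. Compound 1, `CCCn1cc(C(N)=O)c2c(N)ncnc21`, differs from compound 3 by ethyl in place of ethoxy on a saturated chain carbon bound to an aromatic nitrogen. In this assay compound 1 gives 100000 nM. The step of a number no higher from compound 3 to compound 1 (the limit leaves the size open) is a number no higher, its size left open, because of the limit of > 100000 nM in this assay, at which 2 of the 3 values shown sit. Compound 4, `CCCn1cc(C#N)c2c(N)ncnc21`, has not yet been measured in this assay. It differs from compound 2 by ethyl in place of ethoxy on a saturated chain carbon bound to an aromatic nitrogen, the same change that was made from compound 3 to compound 1, at the same place. Compound 4 is expected to give 100000 nM, somewhere between 40000 nM and 300000 nM. The step of a number no higher from compound 2 to compound 4 (the limit leaves the size open) is thus expected to be close to flat. That expectation rests on compound 1, which gives 100000 nM in this assay, and on the open step a number no higher from compound 3 to compound 1 (the limit leaves the size open), which gave no sign of a meaningful gain.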

Compound 4, half-maximal inhibitory concentration: > 100000 nM
Compound 4 was reported as a limit; the forecaster's own chance of this, stated with the estimate: 80%; the middle value lies on the limit itself.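

In this assay compound 4 gives > 100000 nM, which is a limit of the assay and not a number. The step of a number no lower from compound 1 to compound 4 (the limit leaves the size open) comes with cyano in place of carbamoyl on an aromatic carbon. The step from compound 2 to compound 4 cannot be read, because it cannot be sized against this shared limit: the limit of > 100000 nM in this assay, at which 3 of the 4 values shown sit. The change from ethoxymethyl to propyl appears on both the nitrile-bearing compound 2 and the carbamoyl-bearing compound 3, yet neither case has a readable size, so the data show neither that the change carries over from one core to the other nor that it fails to.

What the compounds shown leave open is whether any change at these two places would give a readable value in this cytotoxicity test. A longer chain in place of propyl, or an amine or a carboxylic acid in place of the nitrile or carbamoyl group, remains untested among the compounds shown here.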